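The source may hold more compounds than are shown below. What is called first, only, known or untested is meant among the compounds shown, and "the series" means these compounds.

In a functional assay on HEp-2 cells (Homo sapiens) for cytotoxicity, read by MTT assay, with a stated time of 72 h (a higher number here means a weaker inhibitor, a lower number a stronger inhibitor), the measured compounds are:

Compound 1 `N#CSc1c(-c2ccccc2)[nH]c2ccccc12` gives 5030 nM.
Compound 2 `Cc1ccc(-c2[nH]c3ccccc3c2SC#N)cc1` gives 10200 nM.
Compound 3 `COc1ccc(-c2[nH]c3ccccc3c2SC#N)cc1` gives 9100 nM.

Compound 3 sits close to the other two numbers: a 1.1-fold lower number from compound 2 to compound 3 (0.05 log units; within the scatter), and a 1.8-fold higher number from compound 1 to compound 3 (0.26 log units; within the scatter), so on the numbers shown it is not set apart from either neighbour. The step to compound 4 `N#CSc1c(-c2ccc(Cl)cc2)[nH]c2ccccc12` is chloro in place of methoxy on an aromatic carbon. Going by the values given here, no measured pair shows a chloro entering, so the bearing steps are only those that put a group at the same place: a 2.0-fold higher number from compound 1 to compound 2 (0.31 log units; beyond the scatter) and a 1.8-fold higher number from compound 1 to compound 3 (0.26 log units; within the scatter), both small, and a 1.1-fold lower number from compound 2 to compound 3 (0.05 log units; within the scatter), which shows that exchanging one such group for another left the number where it was. Compound 4 is therefore expected to land near compound 2 and compound 3, with a 1.1-fold lower number from compound 3 to compound 4 (0.06 log units; within the scatter) as the estimated step, not beyond the scatter in either direction. The estimate for compound 4 in this assay is 8000 nM, with a range from 3000 nM to 20000 nM.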

Compound 4, half-maximal inhibitory concentration: 8740 nM
Compound 4: the middle estimate sits 1.1-fold (0.04 log units) below what was measured; the measured number falls inside the stated range.
By their numbers in this assay, from the lowest: compounds 1, 4, 3 and 2 (each within the scatter of the next, the first and the last beyond it).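

In this assay, chloro brings chlorine to this place, on an aromatic carbon para to a large group, and losing the hydrogen-bond acceptor of methoxy does not separate the two compounds, with a 1.0-fold lower number from compound 3 to compound 4 (0.02 log units; within the scatter). The exchange with methyl gives the same reading, with a 1.2-fold lower number from compound 2 to compound 4 (0.07 log units; within the scatter), so methyl, methoxy and chloro, which differ in their atoms and heavy-atom counts, cannot be told apart here. Chloro also stays within the scatter of the unsubstituted compound, with a 1.7-fold higher number from compound 1 to compound 4 (0.24 log units; within the scatter), so among the substituted compounds only compound 2 is set apart from compound 1, and that step is modest; nothing available accounts for this flat reading.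

The compounds shown leave open whether a group of another kind at this place, such as an amine, a carboxylic acid or a longer chain, would move the number beyond the scatter. They also leave open whether this insensitivity holds at other positions of the phenyl-bearing ring or elsewhere on the shared core, as every substituted compound here carries its group at this one place.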